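Carbonyl group swap from compound 3 to compound 4

This account rests on a few compounds, and the source may have more. Where it says the series, first, only, none or still open, it means among the compounds named here.

Compound 1 `O=C1c2ccccc2C(=O)N1CCOC(=S)N(C(=O)c1c(F)cccc1F)c1ccc(Cl)cc1`: 39000 nM
Compound 2 `Cc1ccc2c(c1)C(=O)N(CCOC(=S)N(C(=O)c1cccc([N+](=O)[O-])c1)c1ccc(Cl)cc1)C2=O`: > 100000 nM, a limit
Compound 3 `Cc1ccc2c(c1)C(=O)N(CCOC(=S)N(C(=O)c1cccs1)c1ccc(Cl)cc1)C2=O`: > 100000 nM, a limit

In an ADME assay on MT4 cells (Homo sapiens) for cytotoxicity, read by MTT assay (a lower number here means that less compound is tolerated, a higher number that more compound is tolerated), compound 3 gives only a limit, > 100000 nM, and so no number. It stands at the limit of > 100000 nM in this assay, at which 2 of the 3 values shown sit. Compound 4 `Cc1ccc2c(c1)C(=O)N(CCOC(=S)N(C(=O)c1cccnc1Cl)c1ccc(Cl)cc1)C2=O` is reached from compound 3 by 2-chloropyridin-3-yl in place of thiophen-2-yl on a carbonyl carbon. For the measured compounds named here, the only measured step at this place is a step that the two limits leave unreadable from compound 2 to compound 3, so it offers neither size nor direction. Going by the values given here, compound 1 supplies the sole number, 39000 nM, so a modest fall in this assay is expected. A result at the limit is about as likely. The expected step is an at least 1.1-fold lower number from compound 3 to compound 4 (0.04 log units; that floor lies within the scatter). For compound 4 the estimated value is 90000 nM, with an expected range from 35000 nM to 180000 nM.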

Compound 4, half-maximal cytotoxic concentration: 49000 nM
Beside the measured number, compound 4's estimate is 1.8-fold (0.26 log units) above it; low and high end bracket the measured number.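

In this assay, for the compounds shown here, 2-chloropyridin-3-yl on the carbonyl carbon gives the first readable number for this position on this core, with an at least 2.0-fold lower number from compound 3 to compound 4 (0.30 log units; that floor lies within the scatter) and an at least 2.0-fold lower number from compound 2 to compound 4 (0.30 log units; that floor lies within the scatter). Compound 2 and compound 3 each give only a limit, not a number: the limit of > 100000 nM in this assay, at which 2 of the 4 values shown sit. The step between those two cannot be read, so 2-chloropyridin-3-yl provides the only number among these three groups.

The compounds shown do not separate the part played by the chlorine from that of the ring nitrogen. As far as these compounds go, how an amine or a carboxylic acid on this ring would read remains open.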